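Para substituent swap on the sulfonamide aryl ring

This account rests on a few compounds, and the source may have more. Where it says the series, first, only, none or still open, it means among the compounds named here.

Measured so far:
compound 1 `CC(C)(C)c1ccc(NS(=O)(=O)c2cccc(CCCCCCNC(=O)/C=C/c3cccnc3)c2)cc1`: 9.47 nM
compound 2 `O=C(/C=C/c1cccnc1)NCCCCCCc1cccc(S(=O)(=O)Nc2ccc(Cl)cc2)c1`: 10.8 nM

Going by the values given here, in an assay on isolated protein for inhibition of Nicotinamide phosphoribosyltransferase (Homo sapiens), read by WST assay, with stated times of 60 min, 5 min and 30 min, in the presence of a further agent that is not named here (a lower number here means a stronger inhibitor, a higher number a weaker inhibitor), compound 2 gives 10.8 nM and compound 1 gives 9.47 nM; the one measured step, a 1.1-fold higher number from compound 1 to compound 2 (0.06 log units; within the scatter), lies within the scatter, so compound 2 stands level with compound 1 on these numbers. Compound 3 `O=C(/C=C/c1cccnc1)NCCCCCCc1cccc(S(=O)(=O)Nc2ccc(C(F)(F)F)cc2)c1` carries the change (trifluoromethyl in place of chloro on an aromatic carbon). Among the compounds with values here, the sole step that bears on it is a 1.1-fold higher number from compound 1 to compound 2 (0.06 log units; within the scatter), which exchanged one para group for another without moving the number beyond the scatter. The step of a 1.0-fold lower number from compound 2 to compound 3 (0.01 log units; within the scatter) is therefore expected to stay within the scatter. Compound 3 is estimated at 10.5 nM, with a range of 5 nM to 22 nM.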

Compound 3, half-maximal inhibitory concentration: 24.5 nM
Estimate against measurement, compound 3: 2.3-fold (0.37 log units) below, and the stated range ends below it.
By their numbers in this assay, from the lowest: compounds 1 and 2 (each within the scatter of the next); then compound 3.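

In this assay, this position does not take every group alike: trifluoromethyl in place of chloro gives a modest rise (a 2.3-fold higher number from compound 2 to compound 3 (0.36 log units; beyond the scatter)), and trifluoromethyl in place of tert-butyl gives another (a 2.6-fold higher number from compound 1 to compound 3 (0.41 log units; beyond the scatter)). Both steps lie beyond the scatter, so the level reading of compound 1 and compound 2 does not extend to compound 3. No data at hand give a reason for this. Still open, as far as these compounds go, is whether fluoro, methoxy or an amine at this position reads like compound 1 or like compound 3.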